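The compounds below may be only part of what the source reports. "The series", "measured", "known", "first", "only" and "open" are said of these compounds alone.

Compound 1 `CCN1CCN(CC(=O)Nc2nc3ccccc3[nH]2)CC1`: 65.8%
Compound 2 `COc1ccc(N2CCN(CC(=O)Nc3nc4ccccc4[nH]3)CC2)cc1`: 63.7%

In a functional assay, read by spectrophotometry, with a stated time of 30 min, tested at 200 ug/mL (a higher number here means a stronger effect of the compound at the concentration tested, a lower number a weaker effect), compound 2 gives the lowest of the two numbers, but the nearest, compound 1, stands only a number 2.1 percentage points lower from compound 1 to compound 2 (within the scatter), so the two are not distinguished. Compound 3 `COc1ccccc1N1CCN(CC(=O)Nc2nc3ccccc3[nH]2)CC1` differs from compound 2 as follows (2-methoxyphenyl in place of 4-methoxyphenyl on an amine nitrogen in a ring). Within the data shown here, the only measured step, a number 2.1 percentage points lower from compound 1 to compound 2 (within the scatter), concerns a different change on the same ring nitrogen and was within the scatter, so no evidence points to a shift in this assay beyond the scatter. Compound 3 is expected to give about 62%, with a range from 45% to 78%, a step of a number 1.7 percentage points lower from compound 2 to compound 3 (within the scatter) that is itself an estimate.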

Compound 3, a percentage reported as activity, at one concentration (the size of the read-out at that concentration, not a potency): 64.5%
For compound 3 the middle estimate is 2.5 percentage points below the measured one, and the stated range covers the measured number.
By their numbers in this assay, from the lowest: compounds 2, 3 and 1 (each within the scatter of the next).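

In this assay, 2-methoxyphenyl in place of 4-methoxyphenyl gives a number 0.8 percentage points higher from compound 2 to compound 3 (within the scatter), and 2-methoxyphenyl in place of ethyl gives a number 1.3 percentage points lower from compound 1 to compound 3 (within the scatter), on the same ring nitrogen. So in these three compounds, neither where the methoxy group sits on the phenyl ring nor swapping ethyl for either methoxyphenyl group separates the numbers. No measurement here offers an explanation for this. Still open, as far as these compounds go, is whether a different group on this nitrogen, such as a carboxylic acid, an amine or a longer chain, would move the number beyond the scatter.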